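The compounds below may be only part of what the source reports. "The series", "measured", "known", "first", "only" and "open" are said of these compounds alone.

Among the measured compounds shown here, in a functional assay on MT4 cells (Homo sapiens), read by MTT assay (a lower number here means that less compound is tolerated, a higher number that more compound is tolerated), compound 3 (`C#C[C@]1(CO)O[C@@H](n2cc(F)c(=O)[nH]c2=O)C[C@@H]1O`) gives 3400 nM, the only exact number so far. Compound 1 (`C#C[C@]1(CO)O[C@@H](n2cc(CC)c(=O)[nH]c2=O)C[C@@H]1O`) reads > 360000 nM, which is a limit of the assay. Compound 2 (`C#C[C@]1(CO)O[C@@H](n2ccc(=O)[nH]c2=O)C[C@@H]1O`) reads > 100000 nM, also a limit.

Compound 4 (`C#C[C@]1(CO)O[C@@H](n2cc(I)c(=O)[nH]c2=O)C[C@@H]1O`) keeps the shared core and changes one group: iodo in place of fluoro on an aromatic carbon, with iodo in place of fluoro on an aromatic carbon. For the measured compounds named here, no measured step covers this exchange directly. The nearest evidence is an at least 100-fold lower number from compound 1 to compound 3 (2.02 log units; beyond the scatter) and an at least 29-fold lower number from compound 2 to compound 3 (1.46 log units; beyond the scatter); both are large and both end at the fluoro compound. The step between the other two, a step that the two limits leave unreadable from compound 1 to compound 2, adds nothing.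

Among these three compounds, only fluoro brings the number down into the measurable range, while ethyl and hydrogen both stay at limits. Iodo is a fourth group, so this support is thin. With fluoro gone, a large step upward is still expected in this assay, since compound 3 sits low by an at least 29-fold lower number from compound 2 to compound 3 (1.46 log units; beyond the scatter), and compound 4 may itself end at a limit. The expected step is a 15-fold higher number from compound 3 to compound 4 (1.17 log units; beyond the scatter). For compound 4 the estimated value is 50000 nM, with an expected range from 7000 nM to 300000 nM.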

Compound 4, half-maximal cytotoxic concentration: > 260000 nM
Compound 4 was reported as a limit; the forecaster's own chance of this, stated with the estimate: 45%; at least 5.2-fold (0.71 log units) between middle value and limit.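

In this assay, iodo in place of fluoro gives an at least 76-fold higher number from compound 3 to compound 4 (1.88 log units; beyond the scatter), so the low number of compound 3 does not carry over from fluoro to iodo at this position, even though both groups count as 1 heavy atom with no hydrogen-bond donors or acceptors. Compound 4 is held at a limit and not at a number: the limit of > 260000 nM in this assay, at which 1 of the 4 values shown sits. With ethyl, hydrogen and iodo all ending at limits, fluoro is now the only one of the four groups shown here to give an exact number, and the steps among compound 1, compound 2 and compound 4 cannot be read.

On these data alone, the different limits of those three compounds therefore give no order among them, and how far any of them lies from the others stays unknown. As far as these compounds go, it also stays open whether chloro or bromo, an amine or a longer chain at this position would give an exact number near that of compound 3 or end at a limit as well, and so whether the low number belongs to fluoro alone.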